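Amide ring swap from compound 3 to compound 4

The source may report more compounds than this note shows. Statements on the series, on what has been measured and on what is new or still open speak of the compounds shown alone.

Values in a functional assay on HT-29 cells (Homo sapiens) for inhibition, read by colorimetric assay and sulforhodamine B assay, with a stated time of 48 h; a higher number here means a weaker inhibitor of growth, a lower number a stronger inhibitor of growth:
- compound 1 `CCCCCCCCCCCC[C@@H](O)[C@H]1CC[C@H]([C@H](O)CCCCCCCCCCNC(=O)c2cccs2)O1`: 2190 nM
- compound 2 `CCCCCCCCCCCC[C@@H](O)[C@H]1CC[C@H]([C@H](O)CCCCCCCCCCNC(=O)c2ccoc2)O1`: 100000 nM
- compound 3 `CCCCCCCCCCCC[C@@H](O)[C@H]1CC[C@H]([C@H](O)CCCCCCCCCCNC(=O)c2cncs2)O1`: 100000 nM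

Level with compound 2, compound 3 stands at 100000 nM in this assay, and together they hold the highest of the three numbers. Compound 4 `CCCCCCCCCCCC[C@@H](O)[C@H]1CC[C@H]([C@H](O)CCCCCCCCCCNC(=O)c2ccnn2C)O1` is still unmeasured. Its difference is 1-methyl-1H-pyrazol-5-yl in place of 1,3-thiazol-5-yl on a carbonyl carbon, with 1-methyl-1H-pyrazol-5-yl in place of 1,3-thiazol-5-yl on a carbonyl carbon.

Three measured steps at this same place bear on the change. Both a 46-fold higher number from compound 1 to compound 2 (1.66 log units; beyond the scatter) and a 46-fold higher number from compound 1 to compound 3 (1.66 log units; beyond the scatter) are large and beyond the scatter, while no change at the digits printed from compound 2 to compound 3 (within the scatter) lies within it. Among these three compounds, only compound 1 departs from the high number. Among the measured compounds shown here, no measured compound carries the entering ring, so the expectation is loose, and the range reaches well toward compound 1 at 2190 nM. The expected step is a 1.4-fold lower number from compound 3 to compound 4 (0.15 log units; within the scatter), which is none beyond the scatter. The estimated value for compound 4 is 70000 nM, with an expected range of 4000 nM to 100000 nM.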

Compound 4, concentration for 50% growth inhibition: 100000 nM
Beside the measured number, compound 4's estimate is 1.4-fold (0.15 log units) below it, within the range that was stated.
By their numbers in this assay, from the lowest: compound 1; then compounds 2, 3 and 4 (each within the scatter of the next).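

In this assay the 1-methyl-1H-pyrazol-5-yl amide gives no change at the digits printed from compound 3 to compound 4 (within the scatter) and also no change at the digits printed from compound 2 to compound 4 (within the scatter) so a third ring on the carbonyl carbon joins the same level. Against the thiophen-2-yl amide the result is a 46-fold higher number from compound 1 to compound 4 (1.66 log units; beyond the scatter) and compound 1 remains the only one of the four apart from that level, which now holds for a ring without sulfur as well as for the sulfur-bearing 1,3-thiazol-5-yl of compound 3. Nothing available on these compounds accounts for this separation.

As far as these compounds go, whether the lower number of compound 1 depends on thiophen-2-yl itself stays open, and a thiophen-3-yl or phenyl ring on the same carbonyl carbon would test that. Also open, from the compounds shown here alone, is whether a shorter chain joining the amide nitrogen to the core would alter the number of compound 1.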